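A few compounds are considered here, and "the series" means these few. Any claim that something is new, unique, unknown or untested is made for them only; others in the source may bear on it.

Measured in a functional assay on DU-145 cells (Homo sapiens) for antiproliferative activity, read by MTT assay, with a stated time of 48 h; on this read-out lower numbers stand for stronger inhibition and higher numbers for weaker inhibition:
Compound 1 `CN1C(=O)C(O)(Cc2nnn[nH]2)c2cc(F)ccc21`: > 100000 nM, a limit
Compound 2 `O=C1N(Cc2ccc(Br)cc2)c2ccc(F)cc2C1(O)Cc1nnn[nH]1`: 14400 nM
Compound 3 `CCN1C(=O)C(O)(Cc2nnn[nH]2)c2cc(Cl)ccc21`: 21500 nM

Compound 1 stands at the limit of > 100000 nM in this assay, at which 1 of the 3 values shown sits, so it offers a limit and not a number. Compound 4 `CN1C(=O)C(O)(Cc2nnn[nH]2)c2cc(Br)ccc21` has yet to be measured in this assay. It departs from compound 1 in one place: bromo in place of fluoro on an aromatic carbon. This is bromo in place of fluoro on an aromatic carbon.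

Within the data shown here, no measured step makes this exchange. Among the measured compounds shown here, the only measured step, an at least 6.9-fold lower number from compound 1 to compound 2 (0.84 log units; beyond the scatter), lies elsewhere on the molecule, on a saturated chain carbon bound to an amide-type nitrogen in a ring. It bears on the present change only indirectly, as a sign that a single substitution can move this assay beyond the scatter when starting from the limit. Compound 3 gives a measured 21500 nM, and this is the nearest number available as a guide to size.

A modest step towards a lower number is therefore expected, although a reading at the limit remains possible. The expected step is an at least 2.2-fold lower number from compound 1 to compound 4 (0.34 log units; beyond the scatter). For compound 4 the estimated value is 45000 nM, with an expected range from 17000 nM to 100000 nM.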

Compound 4, half-maximal inhibitory concentration: > 100000 nM
Compound 4 gave a limit, no number; the forecaster's own chance of this, stated with the estimate: 30%; at least 2.2-fold (0.34 log units) between middle value and limit.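

Compound 4, like compound 1, gave a limit and not a number, so the step between these two compounds cannot be read: the limit of > 100000 nM in this assay, at which 2 of the 4 values shown sit.

The compounds shown leave open whether bromo in place of fluoro on an aromatic carbon moves the antiproliferative read-out at all, and in which direction.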